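The source may hold more compounds than are shown below. What is called first, only, known or untested is meant among the compounds shown, and "the series" means these compounds.

Compound 3 `Cn1c(=O)cnn(CCCCN2CCN(c3ccccn3)CC2)c1=O` stands at the top of the three numbers in an assay for displacement of a labelled ligand from Adrenergic receptor alpha-1 (Homo sapiens) (on this read-out higher numbers stand for weaker inhibition and lower numbers for stronger inhibition), where compound 3 gives 262 nM. Its nearest neighbour is compound 2 `Cn1c(=O)cnn(CCCCN2CCN(c3ccccc3C#N)CC2)c1=O`, which gives 7.3 nM in this assay, and the furthest is compound 1 `CCOc1ccccc1N1CCN(CCCCn2ncc(=O)n(C)c2=O)CC1`, which gives 1.8 nM in this assay. The corresponding steps read a 36-fold higher number from compound 2 to compound 3 (1.55 log units; beyond the scatter) and a 150-fold higher number from compound 1 to compound 3 (2.16 log units; beyond the scatter), while between the two aryl variants the change is smaller: a 4.1-fold higher number from compound 1 to compound 2 (0.61 log units; beyond the scatter).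

Compound 4 `Cn1c(=O)cnn(CCCCN2CCN(c3ncccc3F)CC2)c1=O` differs from compound 3 by fluoro in place of hydrogen on an aromatic carbon. Going by the values given here, no measured step carries this exact change. Among the compounds with values here, the only steps that bear on it are those in which the ring on the amine nitrogen carries a group in the same position as this fluoro, and both were large, so a substituent in that position is expected to count. Fluoro is a single heavy atom, so only part of such a gain is expected: for compound 4 the step of a 2.6-fold lower number from compound 3 to compound 4 (0.42 log units; beyond the scatter) is the estimate, giving an expected value of 100 nM for compound 4 in this assay, within 30 nM to 400 nM.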

Compound 4, inhibition constant: > 10000 nM
Compound 4 gave a limit, no number; the forecaster's own chance of this, stated with the estimate: 0%; middle value at least 100-fold (2.00 log units) from the limit.
By their numbers in this assay, from the lowest: compound 1; then compound 2; then compound 3. At a limit, above all of these: compound 4.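

The result for compound 4 in this assay is a limit, not a number: the limit of > 10000 nM in this assay, at which 1 of the 4 values shown sits. Fluoro, a single heavy atom on this aromatic carbon of the pyridin-2-yl ring, moves the number upward, an at least 38-fold higher number from compound 3 to compound 4 (1.58 log units; beyond the scatter), so the low numbers of the 2-ethoxyphenyl and 2-cyanophenyl compounds do not carry over to any group placed here. The gap to those two compounds widens accordingly, an at least 1300-fold higher number from compound 2 to compound 4 (3.13 log units; beyond the scatter) and an at least 5500-fold higher number from compound 1 to compound 4 (3.74 log units; beyond the scatter).

The compounds shown leave open whether this loss belongs to fluoro alone or to any group on this carbon, a question that a chloro, methoxy or nitrile on the same carbon of the pyridin-2-yl ring would address. They also leave open whether fluoro on the matching carbon of a phenyl ring would give the same upward move.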